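Methoxy placement on the anilide-side aryl: compound 3 to compound 4

The compounds below may be only part of what the source reports. "The series", "measured", "known", "first", "only" and "open" are said of these compounds alone.

Measured in a functional assay on MDA-MB-231 cells (Homo sapiens), read by microscopy and transwell migration, with a stated time of 24 h; on this read-out higher numbers stand for weaker inhibition and lower numbers for stronger inhibition:
- compound 1 `COc1cc(-c2csc(NC(=O)c3ccccc3)n2)cc(OC)c1OC`: > 50000 nM (a limit)
- compound 2 `COc1cc(-c2csc(NC(=O)c3cccc(OC)c3OC)n2)cc(OC)c1OC`: 15000 nM
- compound 3 `COc1ccccc1C(=O)Nc1nc(-c2cc(OC)c(OC)c(OC)c2)cs1`: 8500 nM

Among the compounds with values here, compound 3 holds one of only two actual numbers, and the other belongs to compound 2. The two do not separate: a 1.8-fold lower number from compound 2 to compound 3 (0.25 log units; within the scatter). The value of compound 1, > 50000 nM, is a limit of the assay. Against that limit, the series shows an at least 5.8-fold lower number from compound 1 to compound 3 (0.76 log units; beyond the scatter), and also an at least 3.3-fold lower number from compound 1 to compound 2 (0.52 log units; beyond the scatter).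

Compound 4 `COc1cccc(C(=O)Nc2nc(-c3cc(OC)c(OC)c(OC)c3)cs2)c1` has not yet been measured. The change is 3-methoxyphenyl in place of 2-methoxyphenyl on a carbonyl carbon. Within the data shown here, no measured compound carries this group alone, so the evidence is indirect. The step of an at least 5.8-fold lower number from compound 1 to compound 3 (0.76 log units; beyond the scatter) suggests that a single methoxy can matter, while a 1.8-fold lower number from compound 2 to compound 3 (0.25 log units; within the scatter) shows no separation when compound 2 carries one further methoxy. No step beyond the scatter is therefore expected in this assay, with a slight lean towards a higher number. The estimated change is a 1.4-fold higher number from compound 3 to compound 4 (0.15 log units; within the scatter). For compound 4 the expected value is 12000 nM, with an estimated range of 4000 nM to 40000 nM.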

Compound 4, half-maximal inhibitory concentration: 14000 nM
Estimate against measurement, compound 4: 1.2-fold (0.07 log units) below; the measured number falls inside the stated range.
By their numbers in this assay, from the lowest: compounds 3, 4 and 2 (each within the scatter of the next). At a limit, above all of these: compound 1.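

In this assay, moving the single methoxy from 2-methoxyphenyl to 3-methoxyphenyl on a carbonyl carbon gives a 1.6-fold higher number from compound 3 to compound 4 (0.22 log units; within the scatter), so these two placements do not separate. Keeping a methoxy at the 3-methoxyphenyl placement and adding the second one of the 2,3-dimethoxyphenyl group brings no separation either, a 1.1-fold lower number from compound 2 to compound 4 (0.03 log units; within the scatter), whereas the step from the unsubstituted phenyl, an at least 3.5-fold lower number from compound 1 to compound 4 (0.55 log units; beyond the scatter), shows that the separation from compound 1 does not depend on one methoxy placement alone. The same single methoxy therefore counts for much on the plain phenyl and for nothing measurable once another methoxy is already present: the same change on two cores in this assay, an at least 5.8-fold lower number (0.76 log units; beyond the scatter) from compound 1 to compound 3 and a 1.1-fold higher number (0.03 log units; within the scatter) from compound 4 to compound 2, at least 6.3-fold (0.79 log units) apart, beyond the scatter of two such steps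

As far as these compounds go, compound 1 gives > 50000 nM, which is a limit, so the true size of every step from it stays open. Also open, from the compounds shown here alone, are 4-methoxyphenyl on the same carbonyl carbon, a longer chain such as ethoxy in place of methoxy, and an amine or a carboxylic acid on this aryl, any of which could show whether this assay separates changes at this position at all.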